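Series notes: anilino replaced by dipropylamino

This account rests on a few compounds, and the source may have more. Where it says the series, first, only, none or still open, it means among the compounds named here.

Compound 1 `O=C1C(Nc2ccccc2)=CC(=O)c2c1nc1n2[C@H]2OC[C@@H](O)[C@H]2OC1` carries an anilino group on the shared core. In a functional assay on MGC-803 cells (Homo sapiens) for inhibition, read by sulforhodamine B assay (on this read-out lower numbers stand for stronger inhibition and higher numbers for weaker inhibition), compound 1 gives 1830 nM. Compound 2 `O=C1C=C(Nc2ccc(I)cc2)C(=O)c2c1nc1n2[C@H]2OC[C@@H](O)[C@H]2OC1` differs in bearing an iodine on the anilino ring; in this assay compound 2 gives 1400 nM. Compound 1 shows the highest of the two numbers, yet its nearest neighbour is compound 2 and that gap is within the scatter, so no order between the two is claimed.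

Compound 3 `CCCN(CCC)C1=CC(=O)c2c(nc3n2[C@H]2OC[C@@H](O)[C@H]2OC3)C1=O` awaits measurement in this assay. Relative to compound 1 the change is dipropylamino in place of anilino on a double-bonded ring carbon. For the measured compounds named here, no pair of measured compounds reproduces this change, and the two measured points only show that a substituent on the anilino ring leaves the number essentially unchanged. A small step is therefore expected, if anything toward a higher number, and most likely not beyond the scatter. The step from a 1.4-fold higher number from compound 1 to compound 3 (0.15 log units; within the scatter) is what this expectation means. For compound 3 the estimated value in this assay is 2600 nM, with a range from 900 nM to 8000 nM.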

Compound 3, half-maximal inhibitory concentration: > 16000 nM
Compound 3: a limit, no number; the forecaster's own chance of this, stated with the estimate: 5%; at least 6.1-fold (0.78 log units) between middle value and limit.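

In this assay compound 3 gives > 16000 nM, which is a limit of the assay and not a number, so the step that follows fixes only a minimum size because of where this value sits: the limit of > 16000 nM in this assay, at which 1 of the 3 values shown sits.

Dipropylamino in place of anilino on a double-bonded ring carbon gives an at least 8.7-fold higher number from compound 1 to compound 3 (0.94 log units; beyond the scatter), so this position responds to the exchange of its group, which compound 1 and compound 2 could not show, as they stand within the scatter of each other and both keep the anilino group. The exchange leaves the count of heavy atoms unchanged, yet anilino brings a six-membered aromatic ring of carbon only and a hydrogen-bond donor, and dipropylamino brings neither.

The compounds shown leave open which of these two differences goes with the step, as both change together in the only exchange at hand. A propylamino group on the same ring carbon, or a cyclohexylamino group, would keep the amine hydrogen without the aromatic ring and would separate the two.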